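This account rests on a few compounds, and the source may have more. Where it says the series, first, only, none or still open, it means among the compounds named here.

Measured so far:
- compound 1 `Cc1ccc(S(=O)(=O)c2cnc3ccc(C)cc3c2N2CCC(C)CC2)cc1`: 82%
- compound 2 `Cc1ccc(S(=O)(=O)c2cnc3ccc(F)cc3c2N2CCC(C)CC2)cc1Cl`: 91%

In an assay on isolated protein for displacement of a labelled ligand from metabotropic glutamate receptor 5 (Homo sapiens), with a stated time of 60 min, tested at 1 uM (a higher number here means more inhibition at the concentration tested (going by the name of the read-out), a lower number less inhibition), compound 2 gives the higher of the two numbers, but its gap to compound 1 lies within the scatter, so the two are not ordered. Compound 3 `Cc1ccc(S(=O)(=O)c2cnc3ccc(F)cc3c2N2CCC(C)CC2)cc1` differs from compound 2 in one place: hydrogen in place of chloro on an aromatic carbon. Among the measured compounds shown here, no measured pair isolates this change, so the step is expected to be small, with no direction beyond the scatter. Compound 3 is therefore expected to give about 85% in this assay, between 70% and 95%. The expected step of a number 6 percentage points lower from compound 2 to compound 3 (within the scatter) stays within the scatter.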

Compound 3, a percentage reported as inhibition, at one concentration (the size of the read-out at that concentration, not a potency): 91%
Estimate against measurement, compound 3: 6 percentage points below; measured number inside the range.
By their numbers in this assay, from the lowest: compounds 1, 2 and 3 (each within the scatter of the next).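

In this assay, hydrogen in place of chloro on the aromatic carbon ortho to the methyl group gives no change at the digits printed from compound 2 to compound 3 (within the scatter), so the 3-chloro-4-methylphenyl to 4-methylphenyl change shows no effect at this single concentration. Compound 3 also forms a one-place pair with compound 1: fluoro in place of methyl on an aromatic carbon gives a number 9 percentage points higher from compound 1 to compound 3 (within the scatter), which leaves these two compounds unordered. No supporting evidence bears on these results.

Open, from the compounds shown here alone, is whether a methoxy group, a trifluoromethyl group or an amine at the chloro position would give a step beyond the scatter. A single-concentration percentage also gives no potency for any of these compounds.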